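Methylating the ring amide nitrogen of compound 1

A few compounds are considered here, and "the series" means these few. Any claim that something is new, unique, unknown or untested is made for them only; others in the source may bear on it.

Two compounds of the series have numbers in an assay on CHO cells for displacement of a labelled ligand from Substance-P receptor (Homo sapiens); on this read-out lower numbers stand for stronger inhibition and higher numbers for weaker inhibition. Compound 1, `C[C@@H](O[C@H]1CN2C(=O)NC[C@H]2[C@@H]1c1ccc(F)cc1)c1cc(C(F)(F)F)cc(C(F)(F)F)c1`, gives 0.06 nM and stands lowest of the two. Compound 2, `C[C@@H](O[C@@H]1[C@@H](c2ccc(F)cc2)CN2C(=O)OC[C@H]12)c1cc(C(F)(F)F)cc(C(F)(F)F)c1`, gives 1 nM; its number is higher than that of compound 1, and the gap lies beyond the scatter. For the measured compounds named here, the two differ in more than one place, so no single step is counted between them.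

Compound 3, `C[C@@H](O[C@H]1CN2C(=O)N(C)C[C@H]2[C@@H]1c1ccc(F)cc1)c1cc(C(F)(F)F)cc(C(F)(F)F)c1`, is not yet measured. It differs from compound 1 by methyl in place of hydrogen on an amide-type nitrogen in a ring. Going by the values given here, no measured pair differs only at this point, so the series itself shows nothing about this change. Only one carbon enters and the rest of the molecule is unchanged, so a small step is expected, weakening if anything, and possibly none beyond the scatter. For compound 3 in this assay the estimate is 0.12 nM, within 0.03 nM to 0.5 nM. The expected step is a 2.0-fold higher number from compound 1 to compound 3 (0.30 log units; within the scatter).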

Compound 3, half-maximal inhibitory concentration: 0.88 nM
Estimate against measurement, compound 3: 7.3-fold (0.87 log units) below, and the stated range ends below it.
By their numbers in this assay, from the lowest: compound 1; then compounds 3 and 2 (each within the scatter of the next).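

For the compounds shown here, this is the only step that differs in one place, and it falls on an amide-type nitrogen in a ring: in this assay, methyl in place of hydrogen gives a 15-fold higher number from compound 1 to compound 3 (1.17 log units; beyond the scatter), a large step and beyond the scatter. At this position, then, the entry of a single carbon is not a neutral change, and the lower number goes with the amide hydrogen of compound 1. No measurement shown speaks to the reason for this step.

Going by these compounds, whether the same nitrogen would carry an ethyl group, a longer chain or an acetyl group with a similar step remains open. Also open, on these data alone, is whether a hydroxyethyl chain or a carboxylic acid on this nitrogen would bring the number back towards that of compound 1.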